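This account rests on a few compounds, and the source may have more. Where it says the series, first, only, none or still open, it means among the compounds named here.

Working notes on the series.

Compound 1 `CCCCCCCCC(=O)NCC(C)(C)CC1=C(O)C(=O)c2ccccc2C1=O` and compound 2 `CCCCCCCCCCC(=O)NCC(C)(C)CC1=C(O)C(=O)c2ccccc2C1=O` share an amide linker; compound 3 `CCCCCCCCCCCC(=O)OCC(C)(C)CC1=C(O)C(=O)c2ccccc2C1=O` and compound 4 `CCCCCCCCCCCCCC(=O)OCC(C)(C)CC1=C(O)C(=O)c2ccccc2C1=O` carry an ester linker instead. In an ADME assay on Vero cells (Chlorocebus sabaeus) for cytotoxicity, read by reporter gene assay, with a stated time of 4 days (a lower number here means a stronger inhibitor, a higher number a weaker inhibitor), compound 1 gives 16700 nM and compound 2 gives 14900 nM; the change ethyl in place of hydrogen on a saturated chain carbon, eight bonds along the chain from a carbonyl carbon made a 1.1-fold lower number from compound 1 to compound 2 (0.05 log units; within the scatter). Compound 3 gives 249000 nM in this assay. The difference between the core of compound 3 and the core of compound 1 is not broken down here; compound 3 stands well above compound 1 and compound 2 in the number. Going by the values given here, the change ethyl in place of hydrogen on a saturated chain carbon, ten or more bonds along the chain from a carbonyl carbon is the same kind of change as the one from compound 1 to compound 2, though at a different place on the chain. Resting on the step from compound 1 to compound 2, the step of a 1.1-fold lower number from compound 3 to compound 4 (0.03 log units; within the scatter) in this assay is expected to be small. Compound 4 is estimated at 230000 nM in this assay.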

Compound 4, half-maximal inhibitory concentration: 58400 nM
For compound 4 the middle estimate is 3.9-fold (0.60 log units) above the measured one; the whole stated range lies above it.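

In this assay the ethyl in place of hydrogen gives a 4.3-fold lower number from compound 3 to compound 4 (0.63 log units; beyond the scatter) on the ester core, a step beyond the scatter. The change does not carry over at one size between the amide and ester compounds: the same change on two cores in this assay, a 1.1-fold lower number (0.05 log units; within the scatter) from compound 1 to compound 2 and a 4.3-fold lower number (0.63 log units; beyond the scatter) from compound 3 to compound 4, 3.8-fold (0.58 log units) apart, beyond the scatter of two such steps. This does not show what separates the two steps, since the linker and the place on the chain both differ between the pairs and each core rests on a single pair.

Open, as far as these compounds go, is how a longer chain, or an amine or a carboxylic acid in place of the ethyl, would behave on either core in this assay. Assigning the gap to the linker would take an amide and an ester carrying the same chain.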